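Thiourea series: halogen swap on the anilide ring

A few compounds are considered here, and "the series" means these few. Any claim that something is new, unique, unknown or untested is made for them only; others in the source may bear on it.

For the measured compounds named here, compound 1 `O=C(NC(=S)Nc1ccc(F)cc1)c1cn(-c2ccccc2)nc1-c1ccccc1` and compound 2 `O=C(NC(=S)Nc1ccc(Cl)cc1)c1cn(-c2ccccc2)nc1-c1ccc(Cl)cc1` share one core but differ at two places at once, so no single-change step connects them. In a functional assay on MCF7 cells (Homo sapiens) for inhibition, read by CCK-8 assay, with a stated time of 48 h (on this read-out lower numbers stand for stronger inhibition and higher numbers for weaker inhibition), compound 1 gives 6820 nM. In this assay compound 2 gives 5360 nM; against compound 1 the gap lies within the scatter, so the two stand level and nothing separates them. Compound 3 `O=C(NC(=S)Nc1ccc(F)cc1)c1cn(-c2ccccc2)nc1-c1ccc(Cl)cc1` is compound 2 with one change: fluoro in place of chloro on an aromatic carbon, that is, (4-chlorophenyl)amino becomes (4-fluorophenyl)amino while the 4-chlorophenyl on the core stays. Going by the values given here, no measured pair isolates this swap. With compound 1 and compound 2 sitting so close, a step in this assay of no more than the usual scatter is expected, in either direction. Compound 3 is expected at 6000 nM in this assay, with a range from 3000 nM to 12000 nM. The expected step is a 1.1-fold higher number from compound 2 to compound 3 (0.05 log units; within the scatter).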

Compound 3, half-maximal inhibitory concentration: 5990 nM
The estimate for compound 3 lay 1.0-fold (0.00 log units) above the measured number, within the range that was stated.
By their numbers in this assay, from the lowest: compounds 2, 3 and 1 (each within the scatter of the next).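

In this assay the change from (4-chlorophenyl)amino to (4-fluorophenyl)amino, with the 4-chlorophenyl on the core held constant, now stands alone and gives a 1.1-fold higher number from compound 2 to compound 3 (0.05 log units; within the scatter); at this position fluoro and chloro stand level. The other single change, chloro in place of hydrogen that turns the phenyl on the core into 4-chlorophenyl, gives a 1.1-fold lower number from compound 1 to compound 3 (0.06 log units; within the scatter) with (4-fluorophenyl)amino held constant, so this site also shows no separation between the two groups compared. No evidence on the origin of these level results is available.

Both steps cover only hydrogen, fluoro and chloro on aromatic carbons. From the compounds shown here alone, how a methoxy group, an amine or a carboxylic acid at either place would read remains open, as does hydrogen in place of fluoro on the anilide ring.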